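This account rests on a few compounds, and the source may have more. Where it says the series, first, only, none or still open, it means among the compounds named here.

Measured in an assay on membranes from uterus for displacement of a labelled ligand from Angiotensin type II receptor (Sus scrofa), with a stated time of 1.5 h; a higher number here means a weaker inhibitor, a lower number a stronger inhibitor:
- compound 1 `CCCCOC(=O)NS(=O)(=O)c1sc(CC(C)C)cc1-c1ccc(C(=O)c2cccs2)cc1` gives 18.8 nM
- compound 2 `CCCCOC(=O)NS(=O)(=O)c1sc(CC(C)C)cc1-c1ccc(CN2CCCC2=O)cc1` gives 3.5 nM
- compound 3 `CCCCOC(=O)NS(=O)(=O)c1sc(CC(C)C)cc1-c1ccc(Cn2ccc(C(F)(F)F)n2)cc1` gives 9.5 nM

Compound 1 carries the highest number of the three in this assay. Compound 4 `CCCCOC(=O)NS(=O)(=O)c1sc(CC(C)C)cc1-c1ccc(Cc2nnc(C(F)(F)F)o2)cc1` differs from compound 1 at one site: a group of 10 heavy atoms (4 carbon, 2 nitrogen, 1 oxygen, 3 fluorine; one five-membered aromatic ring with 3 hetero atoms) in place of a group of 7 heavy atoms (5 carbon, 1 oxygen, 1 sulfur; one five-membered aromatic ring with 1 hetero atom), on an aromatic carbon. Two measured steps leave from the same position: a 5.4-fold lower number from compound 1 to compound 2 (0.73 log units; beyond the scatter) and a 2.0-fold lower number from compound 1 to compound 3 (0.30 log units; within the scatter). Both replace the (thiophen-2-yl)carbonyl with a methyl-linked ring and both lower the number, one clearly, one within the scatter; a 2.7-fold higher number from compound 2 to compound 3 (0.43 log units; beyond the scatter) separates those two ring types. Compound 4 most resembles compound 3 in its trifluoromethyl-bearing azole on a methylene, so a change of similar size is expected, a 1.9-fold lower number from compound 1 to compound 4 (0.27 log units; within the scatter). Compound 4 is therefore estimated at 10 nM, with a range of 4 nM to 25 nM.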

Compound 4, inhibition constant: 328 nM
Estimate against measurement, compound 4: 33-fold (1.52 log units) below, and the stated range ends below it.
By their numbers in this assay, from the lowest: compound 2; then compounds 3 and 1 (each within the scatter of the next); then compound 4.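

In this assay, among the compounds shown here, the ring on the saturated chain carbon matters far more than the earlier compounds showed: a 35-fold higher number from compound 3 to compound 4 (1.54 log units; beyond the scatter), although both carry a trifluoromethyl group, and a 94-fold higher number from compound 2 to compound 4 (1.97 log units; beyond the scatter). Among the replacements for (thiophen-2-yl)carbonyl, only this one raises the number, a 17-fold higher number from compound 1 to compound 4 (1.24 log units; beyond the scatter). Nothing available here explains the loss.

Going by these compounds, it remains open whether the loss follows the oxadiazole ring or its trifluoromethyl group. A methyl or phenyl group in place of trifluoromethyl on the same ring would separate the two.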